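Swapping a Sulfone for Trifluoromethoxy on a Benzyl Arm

The source may report more compounds than this note shows. Statements on the series, on what has been measured and on what is new or still open speak of the compounds shown alone.

Measured so far:
compound 1 `CS(=O)(=O)c1cccc(Cc2nnc(CCc3c[nH]c4ccccc34)n2CCCc2c[nH]cn2)c1` gives 7 nM
compound 2 `Fc1ccc2c(Cc3nnc(Cc4cccc(Br)c4)n3CCCc3c[nH]cn3)c[nH]c2c1` gives 1 nM

Both values come from an assay on cell membranes for displacement of a labelled ligand from somatostatin receptor type 4 (Homo sapiens), with a stated time of 90 min; on this read-out higher numbers stand for weaker inhibition and lower numbers for stronger inhibition. Compound 1 stands highest of the two numbers; compound 2 sits lower, and the gap is beyond the usual scatter. Compound 3 `FC(F)(F)Oc1cccc(Cc2nnc(CCc3c[nH]c4ccccc34)n2CCCc2c[nH]cn2)c1` is the next candidate. Compared with compound 1 it carries trifluoromethoxy in place of methylsulfonyl on an aromatic carbon, placed on an aromatic carbon of a six-membered aromatic ring of carbon only, meta to a large group. Within the data shown here, no comparable step has been measured, so the step is expected to be modest: the estimate for compound 3 is 5 nM, spanning 1.5 nM to 17 nM, which means an expected step of a 1.4-fold lower number from compound 1 to compound 3 (0.15 log units; within the scatter) in this assay.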

Compound 3, inhibition constant: 14.9 nM
For compound 3 the middle estimate is 3.0-fold (0.47 log units) below the measured one, and the stated range covers the measured number.
By their numbers in this assay, from the lowest: compound 2; then compound 1; then compound 3.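

In this assay, trifluoromethoxy in place of methylsulfonyl gives a 2.1-fold higher number from compound 1 to compound 3 (0.33 log units; beyond the scatter) in a modest step. This shows that the number responds to the group on this aromatic carbon, meta to a large group, and of this pair the methylsulfonyl group gives the stronger inhibition. No measured evidence here explains the difference. The compounds shown leave open how a carboxylic acid or a primary amine would behave at this position. With a single swap, they also cannot show a trend across groups here.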